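A few compounds are considered here, and "the series" means these few. Any claim that something is new, unique, unknown or untested is made for them only; others in the source may bear on it.

Of the compounds shown here, three have so far been read in an ADME assay on HEK-293T cells (Homo sapiens) for cytotoxicity, read by luminescence, with a stated time of 24 h (on this read-out lower numbers stand for higher toxicity in this test and higher numbers for lower toxicity in this test), and none of them gives a number. Compound 1 `COc1ccc(Cn2c(C(=O)N3CCCC3)cc3sccc32)cc1` reads > 100000 nM which is a limit of the assay and not a number. Compound 2 `COc1ccc(Cn2c(C(=O)N3CCN(Cc4ccccc4)CC3)c(COCc3ccccc3)c3sccc32)cc1` reads > 100000 nM which is likewise a limit. Compound 3 `CCCNC(=O)C1CCN(C(=O)c2cc3sc(C(C)=O)cc3n2Cc2ccc(OC)cc2)CC1` reads > 100000 nM and this too is a limit. Within the data shown here, compound 3 thus stands with the other two at the limit of > 100000 nM in this assay, at which 3 of the 3 values shown sit, and no measured step is available to gauge a change.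

Compound 4 `CCCNC(=O)C1CCN(C(=O)c2cc3sc(CNCc4ccccc4)cc3n2Cc2ccc(OC)cc2)CC1` carries (benzylamino)methyl in place of acetyl on an aromatic carbon, next to the ring sulfur (benzylamino)methyl in place of acetyl on an aromatic carbon and is otherwise the same as compound 3. Among the measured compounds shown here, with no measured step to draw on, the expectation in this assay is modest: a small move toward lower numbers, perhaps none beyond the scatter. The only anchor for this expectation is compound 3 at > 100000 nM which remains a limit. The estimated change is an at least 1.2-fold lower number from compound 3 to compound 4 (0.09 log units; that floor lies within the scatter) and it is expected to be small. For compound 4 the estimated half-maximal cytotoxic concentration is 80000 nM with an expected range from 25000 nM to 100000 nM and the assay may well report only a limit.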

Compound 4, half-maximal cytotoxic concentration: 46800 nM
Compound 4: the middle estimate sits 1.7-fold (0.23 log units) above what was measured, within the range that was stated.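

With (benzylamino)methyl in place of acetyl on an aromatic carbon, next to the ring sulfur, this assay gives an at least 2.1-fold lower number from compound 3 to compound 4 (0.32 log units; beyond the scatter), the only step among the compounds shown that can be read, and it shows that a change at this place can bring the read-out down from the limit. Compound 3 reads > 100000 nM, which is a limit of the assay. The step is therefore a floor and not a full size, and compound 4 is the only compound shown that carries a number: the limit of > 100000 nM in this assay, at which 3 of the 4 values shown sit.

The compounds shown leave open which part of the (benzylamino)methyl goes with the step, since the one change brings in both a hydrogen-bond donor and a six-membered aromatic ring of carbon only, and a plain aminomethyl or a benzyl group without the amine at the same carbon would tell these apart. They also leave open whether the same group would lower the number on the cores of compound 1 and compound 2, or with a carboxylic acid in its place.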